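The source may hold more compounds than are shown below. What is called first, only, known or untested is meant among the compounds shown, and "the series" means these compounds.

In an ADME assay on RAW264.7 cells (Mus musculus) for cytotoxicity, read by MTT assay, with a stated time of 24 h (on this read-out lower numbers stand for higher toxicity in this test and higher numbers for lower toxicity in this test), compound 1 (`CC/C=C\C[C@H]1C(=O)C=C[C@H]1CC(=O)Oc1ccc(O)cc1`) with 4-hydroxyphenyl gives 49 uM as its reading. Compound 2 (`CC/C=C\C[C@H]1C(=O)C=C[C@H]1CC(=O)OCCO`) with 2-hydroxyethyl gives 161 uM and compound 3 (`CC/C=C\C[C@H]1C(=O)C=C[C@H]1CC(=O)OCCOC`) with 2-methoxyethyl gives 160 uM on the same read-out. Compound 3 thus stands second highest of the three, within the scatter of compound 2 and beyond the scatter above compound 1. Compound 4 (`CC/C=C\C[C@H]1C(=O)C=C[C@H]1CC(=O)OC(C)(C)C`) has yet to be measured. It differs from compound 3 by tert-butyl in place of 2-methoxyethyl on an oxygen next to a carbonyl group. For the measured compounds named here, no measured compound carries tert-butyl, so the evidence is indirect. Two measured steps at this same place leave 4-hydroxyphenyl, and both are modest (a 3.3-fold higher number from compound 1 to compound 2 (0.52 log units; beyond the scatter); a 3.3-fold higher number from compound 1 to compound 3 (0.51 log units; beyond the scatter)). The step between the two groups without a ring stays within the scatter (a 1.0-fold lower number from compound 2 to compound 3 (0.00 log units; within the scatter)). Tert-butyl also has no ring, so compound 4 is expected to read nearer compound 3 (160 uM) than compound 1 (49 uM) in this assay and the data give no firm direction. For compound 4 the estimated change is small (a 1.2-fold lower number from compound 3 to compound 4 (0.09 log units; within the scatter)) and is not expected to pass beyond the scatter. The expected value for compound 4 is 130 uM (estimated range 60 uM to 280 uM).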

Compound 4, half-maximal toxic concentration: 33 uM
The estimate for compound 4 lay 3.9-fold (0.60 log units) above the measured number; the whole stated range lies above it.
By their numbers in this assay, from the lowest: compounds 4 and 1 (each within the scatter of the next); then compounds 3 and 2 (each within the scatter of the next).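

In this assay, for the compounds shown here, the earlier compounds suggested that this position tolerated a change among groups without a ring, but tert-butyl, which also has no ring, breaks that pattern: replacing 2-methoxyethyl gives a clear fall (a 4.8-fold lower number from compound 3 to compound 4 (0.69 log units; beyond the scatter)), and replacing 2-hydroxyethyl gives a fall of similar size (a 4.9-fold lower number from compound 2 to compound 4 (0.69 log units; beyond the scatter)). The absence of a ring therefore does not place a group with compound 2 and compound 3, even though tert-butyl and 2-methoxyethyl both hold 4 heavy atoms; compound 4 instead stays within the scatter of compound 1, which carries 4-hydroxyphenyl (a 1.5-fold lower number from compound 1 to compound 4 (0.17 log units; within the scatter)). Nothing available here accounts for this shift in the reading. What the compounds shown leave open is whether the lower reading goes with the branched shape of tert-butyl or with the change from a chain containing oxygen to one of carbon alone. A straight butyl chain or an isopropyl group on the same oxygen would help separate the two, as would a 2-aminoethyl group for the wider scope of this position.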